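This account rests on a few compounds, and the source may have more. Where it says the series, first, only, none or still open, it means among the compounds named here.

Compounds measured in a functional assay on Hep2C cells (Homo sapiens) for antiproliferative activity, read by MTT assay, with a stated time of 24 h; a lower number here means a stronger inhibitor, a higher number a weaker inhibitor:
- compound 1 `Clc1ccc(-c2cc(-c3ccccc3)c3cc(Br)ccc3n2)cc1`: 269000 nM
- compound 2 `O=[N+]([O-])c1ccc2c(-c3ccccc3)cc(-c3ccccc3)nc2c1`: "not determined" (no result reported)
- compound 3 `COc1cc(-c2cc(-c3ccccc3)c3cc(Br)ccc3n2)cc(OC)c1OC`: "not determined" (no result reported)

Compound 1 is the only one of these with a number, so it cannot be ranked against anything. For the measured compounds named here, neither compound 2 nor compound 3 offers a comparison, and no pair of measured compounds shows what a structural change does in this assay. Any forecast therefore starts from a single point.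

The next compound to be tested is compound 4 `Fc1ccc(-c2cc(-c3ccccc3)c3cc(Br)ccc3n2)cc1`. It keeps the core of compound 1 and changes one atom: fluoro in place of chloro on an aromatic carbon. In words, this is fluoro in place of chloro on an aromatic carbon, or 4-chlorophenyl to 4-fluorophenyl. Going by the values given here, the swap is small, and no measured step shows how this series responds to it. The forecast therefore stays close to compound 1 at 269000 nM, and a wide range is the honest choice. No shift beyond the usual scatter of repeated measurements is expected in this assay, and no direction can be favoured. The expected change is a 1.1-fold lower number from compound 1 to compound 4 (0.03 log units; within the scatter), an estimate that amounts to little movement. For compound 4 the estimated value is 250000 nM, with an expected range of 100000 nM to 600000 nM.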

Compound 4, half-maximal inhibitory concentration: 5000 nM
The estimate for compound 4 lay 50-fold (1.70 log units) above the measured number, outside the stated range (below it).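

In this assay, for the compounds shown here, replacing chloro with fluoro on the aromatic carbon of the outer ring gives a 54-fold lower number from compound 1 to compound 4 (1.73 log units; beyond the scatter) and is the first measured sign of how this series responds to a structural change. It shows that this position, para to a large group, is far from indifferent: one heavy atom leaves, one heavy atom enters, neither group adds a ring, a charge, or a hydrogen-bond donor or acceptor, and yet the step lies well beyond the usual scatter of repeated measurements. Nothing available here accounts for a step of this size from so small a change.

This single pair leaves open whether the step is specific to fluoro or whether other groups at the same carbon, such as a plain hydrogen, a methyl, an amine or a carboxylic acid, would give a similarly low number. It also leaves open whether the same chloro-to-fluoro exchange would have a comparable effect at another position or on a core carrying something other than the bromo of compound 4.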